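Removing One Phosphate Unit from Two Diphosphate Analogues

The compounds below may be only part of what the source reports. "The series", "measured", "known", "first", "only" and "open" are said of these compounds alone.

Compound 1 `O=c1ccn([C@@H]2O[C@H](COP(=O)(O)OP(=O)(O)O)[C@@H](O)[C@H]2O)c(=S)[nH]1` and compound 2 `Cc1cc(=O)n([C@@H]2O[C@H](COP(=O)(O)OP(=O)(O)O)[C@@H](O)[C@H]2O)c(=O)[nH]1` carry the same diphosphate chain on different cores; the difference between the two cores is not broken down here. In an in vitro functional assay on 1321-N1 cells for agonist activity at P2Y purinoceptor 2 (Homo sapiens) (a lower number here means that less compound is needed, a higher number that more compound is needed for the effect), compound 1 gives > 1000 nM, which is a limit of the assay. In this assay compound 2 gives > 1000 nM, also a limit. Compound 3 `O=c1ccn([C@@H]2O[C@H](COP(=O)(O)O)[C@@H](O)[C@H]2O)c(=S)[nH]1` comes from compound 1 through (a hydrogen atom in place of a group of 4 heavy atoms (3 oxygen, 1 phosphorus; no ring), on an oxygen). In this assay compound 3 gives >= 100000 nM, again a limit. The step that the two limits leave unreadable from compound 1 to compound 3 cannot be sized because the limit of > 1000 nM in this assay, at which 2 of the 3 values shown sit, and the limit of >= 100000 nM in this assay, at which 1 of the 3 values shown sits, bound both of its ends. Compound 4 `Cc1cc(=O)n([C@@H]2O[C@H](COP(=O)(O)O)[C@@H](O)[C@H]2O)c(=O)[nH]1` is the same change made on compound 2, namely (a hydrogen atom in place of a group of 4 heavy atoms (3 oxygen, 1 phosphorus; no ring), on an oxygen). For compound 4 the expected step is a step that the limit leaves unreadable from compound 2 to compound 4, resting on compound 3 and its reading of >= 100000 nM in this assay. Compound 4 is therefore estimated at 100000 nM, between 20000 nM and 500000 nM.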

Compound 4, half-maximal effective concentration: > 100000 nM
Compound 4 ended at the assay's limit; the forecaster's own chance of this, stated with the estimate: 90%; the middle value sits exactly at the limit.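

Compound 2 and compound 4 both stand at limits of this assay, so no step can be read between them. The compounds shown leave open how large the change from losing one phosphate unit is on either core.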